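Heteroaryl Exchange in a Bombesin Receptor Subtype-3 Agonist Series

The compounds below may be only part of what the source reports. "The series", "measured", "known", "first", "only" and "open" are said of these compounds alone.

Compound 1 `CCC(C)(C)Cc1c[nH]c(CCc2ccc(-c3cccc(N)n3)cc2)n1` gives 97 nM in a functional assay on HEK293 cells for agonist activity at Bombesin receptor subtype-3 (Homo sapiens), read by luminescence and calcium flux, with a stated time of 10 min; a higher number here means that more compound is needed for the effect, a lower number that less compound is needed.
Compound 2 `CCC(C)(C)Cc1c[nH]c(CCc2ccc(-c3csnn3)cc2)n1` gives 104 nM in this assay.
Compound 3 `CCC(C)(C)Cc1c[nH]c(CCc2ccc(-c3cnccn3)cc2)n1` gives 100 nM in this assay.

All three share one core and differ only in the aromatic ring attached to it. Compound 3 sits among the other two, and the steps of a 1.0-fold higher number from compound 1 to compound 3 (0.01 log units; within the scatter), a 1.0-fold lower number from compound 2 to compound 3 (0.02 log units; within the scatter) and a 1.1-fold higher number from compound 1 to compound 2 (0.03 log units; within the scatter) all lie within the scatter. Compound 4 `CCC(C)(C)Cc1c[nH]c(CCc2ccc(-n3ncnn3)cc2)n1` has not yet been measured; it differs from compound 3 by 2H-tetrazol-2-yl in place of pyrazin-2-yl on an aromatic carbon. The three measured steps bear directly on this change: each exchanged one heterocycle for another at the same carbon, and none moved the number beyond the scatter. The step from compound 3 to compound 4 is therefore expected to be no change at the digits printed from compound 3 to compound 4 (within the scatter), with nothing beyond the scatter. Compound 4 is estimated at 100 nM, within a range from 45 nM to 220 nM.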

Compound 4, half-maximal effective concentration: 89 nM
The estimate for compound 4 lay 1.1-fold (0.05 log units) above the measured number, within the range that was stated.
By their numbers in this assay, from the lowest: compounds 4, 1, 3 and 2 (each within the scatter of the next).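

Pyrazin-2-yl gives way here to 2H-tetrazol-2-yl, a ring with 4 hetero atoms rather than 2, yet every step to compound 4 stays within the scatter (from a 1.1-fold lower number from compound 3 to compound 4 (0.05 log units; within the scatter)), (a 1.2-fold lower number from compound 2 to compound 4 (0.07 log units; within the scatter)) and (a 1.1-fold lower number from compound 1 to compound 4 (0.04 log units; within the scatter)). At this aromatic carbon, the four heteroaryl rings shown therefore cannot be told apart by their numbers. No measured evidence is available to explain this sameness.

As far as these compounds go, whether a carboxylic acid or a morpholine ring at this carbon would also leave the number within the scatter remains open. So does the effect of removing the ring altogether, leaving only hydrogen there.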